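This account rests on a few compounds, and the source may have more. Where it says the series, first, only, none or still open, it means among the compounds named here.

Values in a functional assay on ileum (strain Hartley) for agonist activity at 5-hydroxytryptamine receptor 3A (Cavia porcellus); on this read-out higher numbers stand for higher potency (the scale is a negative logarithm) and lower numbers for lower potency:

compound 1 `Cc1cc(Cl)c2oc(N3CCN(C)CC3)nc2c1` gives 6.22
compound 2 `COc1cc(C)cc2nc(N3CCN(C)CC3)oc12` gives 6.13

Within the data shown here, compound 2 holds the lowest of the two numbers in this assay, with compound 1 nearest to it; the one measured step, a number 0.09 log units lower from compound 1 to compound 2 (within the scatter), lies within the scatter, so the two measured compounds are not separated on this read-out.

Compound 3 `Cc1cc(C)c2oc(N3CCN(C)CC3)nc2c1` is the next compound in the series. It differs from compound 2 in one place: methyl in place of methoxy on an aromatic carbon.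

Among the measured compounds shown here, the only measured step that bears on this change is the one in which a methoxy group entered at an aromatic carbon of the same core in place of chloro, and that step was within the scatter. A change of a substituent at an aromatic carbon of this core has therefore so far left the read-out essentially unchanged. On this basis the expected step of a number 0.02 log units higher from compound 2 to compound 3 (within the scatter) is none beyond the scatter, in no preferred direction. Compound 3 is thus estimated at 6.15 in this assay, with a range from 5.65 to 6.65.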

Compound 3, negative logarithm of the half-maximal effective concentration: 6.32
For compound 3 the middle estimate is 0.17 log units below the measured one, within the range that was stated.
By their numbers in this assay, from the lowest: compounds 2, 1 and 3 (each within the scatter of the next).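

In this assay, the position on an aromatic carbon, ortho to a fused ring and meta to a methyl group, has now carried chloro, methoxy and methyl. Placing methyl there in place of methoxy gives a number 0.19 log units higher from compound 2 to compound 3 (within the scatter) and placing it there in place of chloro gives a number 0.10 log units higher from compound 1 to compound 3 (within the scatter) on this read-out. The three compounds therefore remain unseparated, which extends the earlier chloro-to-methoxy result to methyl and shows that, among these three groups, going from methoxy with 1 hydrogen-bond acceptor to methyl with 0 does not separate the numbers; no measurement here bears on why these steps stay so small.

The compounds shown span only three groups of 1 or 2 heavy atoms with no net charge, so it remains open whether an amine, a carboxylic acid or a longer alkyl chain at this position would move the number beyond the scatter. Also open, as far as these compounds go, is whether the read-out is as indifferent to changes elsewhere, since the other methyl group and the rest of the shared core stay the same throughout.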